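Swapping the Anilino Ring Back Toward a Halogenated Pattern

The source may report more compounds than this note shows. Statements on the series, on what has been measured and on what is new or still open speak of the compounds shown alone.

Compound 2 `COc1ccc(Nc2ncnc3cc(OC)c(OCCCCC(=O)Nc4ccc(S(N)(=O)=O)cc4)cc23)cc1OC` and compound 1 `COc1cc2ncnc(Nc3cccc(Br)c3)c2cc1OCCCCC(=O)Nc1ccc(S(N)(=O)=O)cc1` share one core and differ only in the ring attached to the nitrogen on the aromatic ring. In a functional assay on A549 cells (Homo sapiens) for antiproliferative activity, read by MTT assay, with a stated time of 72 h (a higher number here means a weaker inhibitor, a lower number a stronger inhibitor), compound 2 reaches only the assay limit of > 40000 nM. In this assay compound 1 gives 14900 nM. For the measured compounds named here, the single measured step, an at least 2.6-fold higher number from compound 1 to compound 2 (0.42 log units; beyond the scatter), runs toward weaker inhibition, and the evidence behind it is the limit of > 40000 nM in this assay, at which 1 of the 2 values shown sits, so its true size is not fixed. Compound 3 `COc1cc2ncnc(Nc3ccc(F)c(Br)c3)c2cc1OCCCCC(=O)Nc1ccc(S(N)(=O)=O)cc1` makes the opposite kind of change: 3-bromo-4-fluorophenyl in place of 3,4-dimethoxyphenyl on a nitrogen on an aromatic ring. The entering ring resembles the 3-bromophenyl of compound 1, carrying an added fluorine, so the measured loss is expected to be largely undone. The expected step is an at least 2.6-fold lower number from compound 2 to compound 3 (0.42 log units; beyond the scatter). For compound 3 the estimate in this assay is 15000 nM, ranging from 5000 nM to 45000 nM.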

Compound 3, half-maximal inhibitory concentration: 16000 nM
Compound 3: middle estimate off by 1.1-fold (0.03 log units), on the low side; low and high end bracket the measured number.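

In this assay, 3-bromo-4-fluorophenyl in place of 3,4-dimethoxyphenyl on the nitrogen gives an at least 2.5-fold lower number from compound 2 to compound 3 (0.39 log units; beyond the scatter), so a second bromine-bearing ring now stands on the stronger side of the dimethoxy ring, where before there was only one. The size of that step is not fixed, since one end of it is an assay limit: the limit of > 40000 nM in this assay, at which 1 of the 3 values shown sits. The other new step, fluoro in place of hydrogen on an aromatic carbon, is a 1.1-fold higher number from compound 1 to compound 3 (0.03 log units; within the scatter), so this added fluorine leaves the number within the scatter.

Whether the bromine or the absence of the two methoxy groups accounts for the difference remains open, as a ring carrying chlorine in place of bromine, or a single methoxy group, is not among the compounds shown. Also open, from the compounds shown here alone, is whether any change on this ring could reach much lower numbers with the same butanamide-type chain and sulfonamide, or whether a shorter chain or a carboxylic acid would matter more.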